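Sulfoxide in place of methylcarbamoyl on the ring carbon

The source may report more compounds than this note shows. Statements on the series, on what has been measured and on what is new or still open speak of the compounds shown alone.

Going by the values given here, compound 3 `CNC(=O)C1(c2cc(F)cc(OCc3ccc(-n4ccnc4C)cc3)c2)CCOCC1` stands at the weak end of the three measured members: in an assay on blood for inhibition of Polyunsaturated fatty acid 5-lipoxygenase (Homo sapiens) (a lower number here means a stronger inhibitor, a higher number a weaker inhibitor), compound 3 gives 280 nM, the highest number of the set. Compound 1 `COC1(c2cc(F)cc(OCc3ccc(-n4ccnc4C)cc3)c2)CCOCC1` gives 60 nM and compound 2 `CCOC1(c2cc(F)cc(OCc3ccc(-n4ccnc4C)cc3)c2)CCOCC1` gives 80 nM. The steps to compound 3 were a 4.7-fold higher number from compound 1 to compound 3 (0.67 log units; beyond the scatter) and a 3.5-fold higher number from compound 2 to compound 3 (0.54 log units; beyond the scatter), while the ether pair differs only by a 1.3-fold higher number from compound 1 to compound 2 (0.12 log units; within the scatter).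

Compound 4 `Cc1nccn1-c1ccc(COc2cc(F)cc(C3([S+](C)[O-])CCOCC3)c2)cc1` differs from compound 3 by a group of 3 heavy atoms (1 carbon, 1 oxygen, 1 sulfur; no ring) in place of a group of 4 heavy atoms (2 carbon, 1 nitrogen, 1 oxygen; no ring), on a saturated ring carbon. The incoming group, like the two ethers, carries no hydrogen-bond donor and one acceptor, whereas the departing methylcarbamoyl carries a donor. Among the compounds with values here, both measured steps bearing on this position show that removing the methylcarbamoyl in favour of a small donor-free group lowers the number beyond the scatter; the sulfur-containing group has no direct precedent, so only a partial return is assumed.

Compound 4 is therefore expected to give 110 nM in this assay, within 40 nM to 320 nM, an expected step of a 2.5-fold lower number from compound 3 to compound 4 (0.41 log units; beyond the scatter).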

Compound 4, half-maximal inhibitory concentration: > 1000 nM
Compound 4 ended at the assay's limit (the forecaster's own chance of this, stated with the estimate: 2%); middle value at least 9.0-fold (0.95 log units) away from the limit.
By their numbers in this assay, from the lowest: compounds 1 and 2 (each within the scatter of the next); then compound 3. At a limit, above all of these: compound 4.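

Compound 4 stands at a limit of this assay, not at a measured number: the limit of > 1000 nM in this assay, at which 1 of the 4 values shown sits.

Even so, the change reads clearly as an at least 3.5-fold higher number from compound 3 to compound 4 (0.55 log units; beyond the scatter), an at least 12-fold higher number from compound 2 to compound 4 (1.09 log units; beyond the scatter) and an at least 16-fold higher number from compound 1 to compound 4 (1.22 log units; beyond the scatter), so the saturated ring carbon does not tolerate every small group equally. Compound 4 matches the two ethers in having no hydrogen-bond donor, yet it lies above compound 3, which carries one, and so the absence of a donor at this position does not by itself keep the number low; compound 4 goes against the trend that compounds 1, 2 and 3 suggested.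

As far as these compounds go, how far compound 4 lies past the limit remains unknown. Whether the sulfur atom or this particular group accounts for the step also stays open, as no sulfone or methylthio group at this ring carbon appears among the compounds shown.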